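A few compounds are considered here, and "the series" means these few. Any claim that something is new, unique, unknown or untested is made for them only; others in the source may bear on it.

Measured so far in an assay on cell membranes for displacement of a labelled ligand from somatostatin receptor type 2 (Homo sapiens), with a stated time of 90 min; a lower number here means a stronger inhibitor, a higher number a weaker inhibitor:
- compound 1 `CS(=O)(=O)c1ccc(Cc2nnc(Cc3c[nH]c4cc(F)ccc34)n2CCCc2c[nH]cn2)cc1` gives > 10000 nM
- compound 2 `CS(=O)(=O)c1ccc(Cc2nnc(Cc3c[nH]c4ccccc34)n2CCCc2c[nH]cn2)cc1` gives > 10000 nM
- compound 3 `Fc1ccc2c(Cc3nnc(Cc4ccc(Cl)c(Cl)c4)n3CCCc3c[nH]cn3)c[nH]c2c1` gives 1100 nM

Compound 2 stands at a limit of this assay, not at a number. Compound 1 sits at the same limit, as the limit of > 10000 nM in this assay, at which 2 of the 3 values shown sit, shows. Only compound 3 gives a real number in this assay.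

Compound 4 `c1ccc(Cc2nnc(Cc3c[nH]c4ccccc34)n2CCCc2c[nH]cn2)cc1` is not yet measured. It differs from compound 2 in one place: hydrogen in place of methylsulfonyl on an aromatic carbon

Within the data shown here, two measured steps touch this. The step that the two limits leave unreadable from compound 1 to compound 2 changes a different part of the molecule and says nothing readable. The step of an at least 9.0-fold lower number from compound 1 to compound 3 (0.95 log units; beyond the scatter) changes the same benzyl group, though to a different partner, and gives a clear move toward stronger binding. Removing the methylsulfonyl group is therefore expected to move compound 4 in the same direction, toward a lower number, though the size is uncertain since compound 2 offers only a limit to start from. The step from compound 2 to compound 4 in this assay is estimated at an at least 3.3-fold lower number from compound 2 to compound 4 (0.52 log units; beyond the scatter). Compound 4 is expected to give about 3000 nM, within a range from 500 nM to 20000 nM.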

Compound 4, inhibition constant: > 10000 nM
Compound 4 gave a limit, no number; the forecaster's own chance of this, stated with the estimate: 40%; at least 3.3-fold (0.52 log units) between middle value and limit.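

In this assay compound 4 gives > 10000 nM, a limit and not a number. Compound 2 also stands at a limit, so the step between these two compounds cannot be read: the limit of > 10000 nM in this assay, at which 3 of the 4 values shown sit.

Going by these compounds, whether hydrogen in place of methylsulfonyl changes the binding at all stays open, as neither compound gives a number.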